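Swapping the aryl group on the sulfonamide nitrogen

This account rests on a few compounds, and the source may have more. Where it says the series, first, only, none or still open, it means among the compounds named here.

In a functional assay on MCF7 cells (Homo sapiens) for antiproliferative activity, read by MTT assay, with a stated time of 72 h (a lower number here means a stronger inhibitor, a higher number a weaker inhibitor), compound 1 (`Cc1ccc(N(C)S(=O)(=O)C2CC3OC2C(c2ccc(NC(=O)CCCCCCC(=O)O)cc2)=C3c2ccc(O)cc2)cc1`) gives 23200 nM, compound 2 (`Cc1cccc(N(C)S(=O)(=O)C2CC3OC2C(c2ccc(NC(=O)CCCCCCC(=O)O)cc2)=C3c2ccc(O)cc2)c1`) gives 30200 nM and compound 3 (`CCN(c1ccc(C)cc1)S(=O)(=O)C1CC2OC1C(c1ccc(NC(=O)CCCCCCC(=O)O)cc1)=C2c1ccc(O)cc1`) gives 42300 nM. Compound 3 stands within the scatter of both others, with a 1.8-fold higher number from compound 1 to compound 3 (0.26 log units; within the scatter) and a 1.4-fold higher number from compound 2 to compound 3 (0.15 log units; within the scatter). Compound 4 (`CCN(c1ccccc1Cl)S(=O)(=O)C1CC2OC1C(c1ccc(NC(=O)CCCCCCC(=O)O)cc1)=C2c1ccc(O)cc1`) carries 2-chlorophenyl in place of 4-methylphenyl on a sulfonamide nitrogen. The nearest evidence is the exchange of 4-methylphenyl for 3-methylphenyl, a 1.3-fold higher number from compound 1 to compound 2 (0.11 log units; within the scatter). Among the compounds with values here, no measured compound carries chlorine, so this support is indirect. In this assay, the expected step is a 1.2-fold lower number from compound 3 to compound 4 (0.08 log units; within the scatter), which means no change beyond the scatter is anticipated. Compound 4 is estimated at 35000 nM, with an expected range of 18000 nM to 70000 nM.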

Compound 4, half-maximal inhibitory concentration: 33300 nM
Compound 4: the middle estimate sits 1.1-fold (0.02 log units) above what was measured; measured number inside the range.
By their numbers in this assay, from the lowest: compounds 1, 2, 4 and 3 (each within the scatter of the next).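

In this assay, 2-chlorophenyl in place of 4-methylphenyl on the sulfonamide nitrogen gives a 1.3-fold lower number from compound 3 to compound 4 (0.10 log units; within the scatter), so this position now holds a chlorine-bearing ring with no change beyond the scatter. The comparisons with the other two sulfonamides agree, at a 1.1-fold higher number from compound 2 to compound 4 (0.04 log units; within the scatter) and a 1.4-fold higher number from compound 1 to compound 4 (0.16 log units; within the scatter). Nothing measured here accounts for this result.

The compounds shown leave open whether an amino group on this aryl ring, or a chain longer than ethyl on the sulfonamide nitrogen, would move the number beyond the scatter.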